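The source may report more compounds than this note shows. Statements on the series, on what has been measured and on what is new or still open speak of the compounds shown alone.

Compound 3 `CC(=O)OC[C@H]1O[C@@H](n2cc(-c3cn(Cc4ccccc4)nn3)c(=O)[nH]c2=O)C[C@@H]1OC(C)=O` was examined in a functional assay on MDA-MB-231 cells (Homo sapiens) for cytotoxicity, read by sulforhodamine B assay, tested at 10 uM (on this read-out higher numbers stand for more inhibition at the one concentration tested (going by the name of the read-out) and lower numbers for less inhibition), and gives 102%. Of the three compounds measured, it shows the top figure, although compound 1 `CC(=O)OC[C@H]1O[C@@H](n2cc(-c3cn(Cc4ccc(C(C)C)cc4)nn3)c(=O)[nH]c2=O)C[C@@H]1OC(C)=O`, which in this assay gives 98.1%, lies within the usual scatter of it, so no order between these two can be claimed. Among the compounds with values here, compound 2 `CC(=O)OC[C@H]1O[C@@H](n2cc(-c3cc(-c4ccc(C(C)(C)C)cc4)no3)c(=O)[nH]c2=O)C[C@@H]1OC(C)=O`, built on a different connecting unit, gives 69.3% in this assay, and this is the one reading that stands beyond the scatter from compound 3.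

Compound 4 `CC(=O)OC[C@H]1O[C@@H](n2cc(-c3cn(Cc4ccc(C(C)(C)C)cc4)nn3)c(=O)[nH]c2=O)C[C@@H]1OC(C)=O` has not yet been measured. It differs from compound 3 in one place: tert-butyl in place of hydrogen on an aromatic carbon. Within the data shown here, one measured step bears on this change, the one in which the same aromatic carbon lost its isopropyl: a number 3.9 percentage points higher from compound 1 to compound 3 (within the scatter). Replacing a branched alkyl by hydrogen at this position thus left the reading where it was, and both compounds already give high numbers at the single concentration tested. Putting a tert-butyl in at the same position is therefore expected to give no step beyond the scatter, a number 5 percentage points lower from compound 3 to compound 4 (within the scatter), and compound 4 is estimated at 97%, with a likely range from 85% to 105%.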

Compound 4, a percentage reported as inhibition, at one concentration (the size of the read-out at that concentration, not a potency): 105%
For compound 4 the middle estimate is 8 percentage points below the measured one, within the range that was stated.
By their numbers in this assay, from the lowest: compound 2; then compounds 1, 3 and 4 (each within the scatter of the next).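

In this assay, the new compound adds a second branched group at this aromatic carbon, and tert-butyl in place of hydrogen gives a number 3 percentage points higher from compound 3 to compound 4 (within the scatter), so the earlier finding for isopropyl also holds for a group of four carbons on the same benzyl unit. Exchanging one branched group for the other gives a number 6.9 percentage points higher from compound 1 to compound 4 (within the scatter), which means that hydrogen, isopropyl and tert-butyl at this carbon can now all be compared directly, and none of the three steps among them stands beyond the scatter. Nothing available explains why these three substituents read alike, and no measurement beyond this single read-out bears on it.

The compounds shown leave open whether this carbon would accept a group of another kind, such as an amine, a carboxylic acid or a methoxy group, since only hydrogen and branched alkyl groups appear there. They also leave open whether the three compounds would still read alike at a lower concentration, since a single high reading at one concentration says nothing about potency.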